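Compound 4: Exchanging the Aromatic Group on the Carbonyl

The source may hold more compounds than are shown below. What is called first, only, known or untested is meant among the compounds shown, and "the series" means these compounds.

Measured in an ADME assay on MT4 cells (Homo sapiens) for cytotoxicity, read by MTT assay; a lower number here means that less compound is tolerated, a higher number that more compound is tolerated:
- Compound 1 `Cc1ccc(N(C(=O)c2cccc(C)c2)C(=S)OCCN2C(=O)c3ccccc3C2=O)cc1`: > 100000 nM
- Compound 2 `COc1cccc(OC)c1C(=O)N(C(=S)OCCN1C(=O)c2ccccc2C1=O)c1ccc(Cl)cc1`: 69000 nM
- Compound 3 `Cc1ccc(N(C(=O)c2cc(F)cc(F)c2)C(=S)OCCN2C(=O)c3ccccc3C2=O)cc1`: 54000 nM

The entry for compound 1 is > 100000 nM, a limit of the assay and not a number. Compound 3, at 54000 nM, lies within the scatter of compound 2, so the two numbers available cannot be told apart.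

Compound 4 `COc1cccc(OC)c1C(=O)N(C(=S)OCCN1C(=O)c2ccccc2C1=O)c1ccc(C)cc1` has not yet been measured. Its change is 2,6-dimethoxyphenyl in place of 3,5-difluorophenyl on a carbonyl carbon, which puts 2,6-dimethoxyphenyl in place of 3,5-difluorophenyl on a carbonyl carbon. One measured step changes the group at this place, an at least 1.8-fold lower number from compound 1 to compound 3 (0.26 log units; that floor lies within the scatter), and it gives only a floor. Compound 2 already carries 2,6-dimethoxyphenyl on a carbonyl carbon and gives 69000 nM, close to the number for compound 3.

In this assay, no step beyond the scatter is therefore expected, and the estimated step is a 1.3-fold higher number from compound 3 to compound 4 (0.12 log units; within the scatter). For compound 4 the expected value is 72000 nM, with an estimated range of 40000 nM to 100000 nM.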

Compound 4, half-maximal cytotoxic concentration: 36000 nM
The estimate for compound 4 lay 2.0-fold (0.30 log units) above the measured number; the whole stated range lies above it.
By their numbers in this assay, from the lowest: compounds 4, 3 and 2 (each within the scatter of the next). At a limit, above all of these: compound 1.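

In this assay the aromatic group on the carbonyl carbon now has a step with a number at both ends, and with a 1.5-fold lower number from compound 3 to compound 4 (0.18 log units; within the scatter) the 2,6-dimethoxyphenyl and 3,5-difluorophenyl groups cannot be told apart. A second place also comes into view, and with a 1.9-fold lower number from compound 2 to compound 4 (0.28 log units; within the scatter) methyl and chloro on an aromatic carbon cannot be told apart either. Only an at least 2.7-fold lower number from compound 1 to compound 4 (0.44 log units; beyond the scatter) lies beyond the scatter, and that step rests on the entry for compound 1, which is a limit: the limit of > 100000 nM in this assay, at which 1 of the 4 values shown sits.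

The compounds shown leave open whether 3-methylphenyl on the carbonyl carbon truly differs from the other two groups once it is read as a number and not a limit. They also leave open how an amine or a carboxylic acid in place of the aromatic group on the carbonyl carbon would read in this assay against these compounds.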